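The compounds below may be only part of what the source reports. "The series", "measured", "known", "first", "only" and "open" are said of these compounds alone.

Three aryl sulfonate esters carrying a cyclic urea on the other ring were compared in a functional assay on MCF7 cells (Homo sapiens) for antiproliferative activity, read by sulforhodamine B assay, with a stated time of 48 h; on this read-out lower numbers stand for stronger inhibition and higher numbers for weaker inhibition. Compound 1 `COc1ccc(OS(=O)(=O)c2ccc(N3CCN(C)C3=O)cc2)cc1OC` gives 12000 nM in this assay. Compound 2 `COc1cc(OS(=O)(=O)c2ccc(N3CCN(C)C3=O)cc2)cc(OC)c1OC` differs from compound 1 by methoxy in place of hydrogen on an aromatic carbon. In this assay compound 2 gives 120 nM, a change described as a 100-fold lower number from compound 1 to compound 2 (2.00 log units; beyond the scatter). Compound 3 `CCCCN1CCN(c2ccc(S(=O)(=O)Oc3ccccc3)cc2)C1=O` gives 8800 nM in this assay; the difference between its core and the core of compound 1 is not broken down here, and its value and that of compound 1 lie within the scatter of each other.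

Compound 4 `CCCCN1CCN(c2ccc(S(=O)(=O)Oc3ccccc3OC)cc2)C1=O` has not yet been measured. It differs from compound 3 by methoxy in place of hydrogen on an aromatic carbon. Among the measured compounds shown here, this is the same kind of change as the one from compound 1 to compound 2, but not the same: in compound 2 the methoxy sits ortho to a methoxy group, meta to a large group and meta to a methoxy group, whereas in compound 4 it sits ortho to a large group. For the measured compounds named here, the only guide is the large step of a 100-fold lower number from compound 1 to compound 2 (2.00 log units; beyond the scatter), which rests on a different surrounding of the entering group, so a smaller step is expected here; the expected step is a 2.0-fold lower number from compound 3 to compound 4 (0.29 log units; within the scatter). Compound 4 is therefore estimated to give 4500 nM in this assay, with a range from 1200 nM to 15000 nM.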

Compound 4, half-maximal inhibitory concentration: 3800 nM
For compound 4 the middle estimate is 1.2-fold (0.07 log units) above the measured one; the range from low to high includes it.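

On the core of compound 3, methoxy in place of hydrogen on an aromatic carbon gave a 2.3-fold lower number from compound 3 to compound 4 (0.36 log units; beyond the scatter) in this assay, so the number fell on both cores, but by very different amounts: the same change on two cores in this assay, a 100-fold lower number (2.00 log units; beyond the scatter) from compound 1 to compound 2 and a 2.3-fold lower number (0.36 log units; beyond the scatter) from compound 3 to compound 4, 43-fold (1.64 log units) apart, beyond the scatter of two such steps Across these two pairs, the direction of the change carries from one core to the other, but the size of the step does not, and the large step seen on the core of compound 1 cannot be taken as a guide for other cores in this series. The comparison does not show what sets the two steps apart: the entering methoxy sits ortho to a large group in compound 4 but ortho to a methoxy group in compound 2, the rings already carry different groups, and the urea nitrogen bears a butyl chain in compound 3 and a methyl group in compound 1, so these differences cannot be separated here.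

As far as these compounds go, it remains open whether the three methoxy groups of compound 2 would give a similarly low number on the butyl core of compound 3, which would separate the effect of the ring from that of the chain. From the compounds shown here alone, it is also open how a hydroxyl group, a fluorine atom or an amine would compare with methoxy at the place it holds in compound 4, and how a longer chain on the urea nitrogen would compare with butyl.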